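A few compounds are considered here, and "the series" means these few. Any claim that something is new, unique, unknown or untested is made for them only; others in the source may bear on it.

Compound 1 `Cn1nc(O)c(C(=O)Nc2cc(C(F)(F)F)cc(C(F)(F)F)c2)n1`: in an assay on isolated protein for inhibition of mitogen-activated protein kinase kinase kinase 14 (Homo sapiens), read by ADP-Glo, with a stated time of 60 min, in the presence of a further agent that is not named here (on this read-out lower numbers stand for stronger inhibition and higher numbers for weaker inhibition), compound 1 gives > 100000 nM, which is a limit of the assay and not a number.
Compound 2 `Cn1nnc(O)c1C(=O)Nc1cc(C(F)(F)F)cc(C(F)(F)F)c1`: in this assay compound 2 gives > 100000 nM, again a limit.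
Compound 3 `O=C(Nc1cc(C(F)(F)F)cc(C(F)(F)F)c1)c1n[nH]nc1O`: in this assay compound 3 gives > 100000 nM, also a limit.

Compound 3 therefore stands where every measured compound stands, at the limit of > 100000 nM in this assay, at which 3 of the 3 values shown sit. The three measured changes tell nothing about size or direction: swapping the ring on the carbonyl carbon gives a step that the two limits leave unreadable from compound 1 to compound 2, removing the methyl from the aromatic nitrogen gives a step that the two limits leave unreadable from compound 1 to compound 3, and the remaining swap gives a step that the two limits leave unreadable from compound 2 to compound 3.

Compound 4 `Nc1nonc1C(=O)Nc1cc(C(F)(F)F)cc(C(F)(F)F)c1` differs from compound 3 by 4-amino-1,2,5-oxadiazol-3-yl in place of 5-hydroxy-2H-1,2,3-triazol-4-yl on a carbonyl carbon. No measured step bears on this change in a readable way, and nothing in the series has yet shown any inhibition. The expectation for compound 4 in this assay is therefore a step that the limit leaves unreadable from compound 3 to compound 4, meaning no step beyond the scatter, most likely another limit. Compound 4 is estimated at 150000 nM, within a range from 30000 nM to 1000000 nM.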

Compound 4, half-maximal inhibitory concentration: > 100000 nM
Compound 4 gave a limit, no number (the forecaster's own chance of this, stated with the estimate: 85%); the middle value does not contradict the limit.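

Compound 4 gives a limit and not a number, like compound 1, compound 2 and compound 3, so none of the steps from those three to compound 4 can be read: the limit of > 100000 nM in this assay, at which 4 of the 4 values shown sit.

The compounds shown leave open whether any group on the carbonyl carbon of this shared core can give a readable inhibition in this assay, and how these groups rank against one another.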